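The source may report more compounds than this note shows. Statements on the series, on what has been measured and on what is new or still open speak of the compounds shown alone.

Working notes on the cytotoxicity series.

Of the compounds shown here, three of the shared core have been measured in an ADME assay on MT4 cells (Homo sapiens) for cytotoxicity, read by MTT assay, with a stated time of 5 days; a higher number here means that more compound is tolerated, a lower number that less compound is tolerated. Compound 1 `Cc1cc(/C=C/C#N)cc(C)c1Oc1cc(NC2CC2)nc(Nc2ccc(C#N)cc2)n1` gives 3000 nM. Compound 2 `COC(Nc1cc(Oc2c(C)cc(/C=C/C#N)cc2C)nc(Nc2ccc(C#N)cc2)n1)OC` gives 3470 nM. Compound 3 `C=CCNc1cc(Oc2c(C)cc(/C=C/C#N)cc2C)cc(Nc2ccc(C#N)cc2)n1` gives 82100 nM. On these numbers compound 2 stands second highest of the three: its nearest neighbour is compound 1, whose value is within the scatter of it, and the furthest is compound 3, which gives a higher number beyond the scatter. Among the measured compounds shown here, compound 3 differs from compound 2 in more than one place, so no single step links them.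

The next compound, compound 4 `Cc1cc(/C=C/C#N)cc(C)c1Oc1cc(NCCN2CCNCC2)nc(Nc2ccc(C#N)cc2)n1`, is not yet measured. Relative to compound 2 the change is 2-(piperazin-1-yl)ethyl in place of dimethoxymethyl on a nitrogen on an aromatic ring.

For the measured compounds named here, only one measured step touches this position: a 1.2-fold higher number from compound 1 to compound 2 (0.06 log units; within the scatter). That step swapped one small group for another and left the number within the scatter. Going by the values given here, the group entering compound 4 is larger and carries a ring and a donor, for which the measured set gives no precedent. With nothing pointing in either direction, the expectation for compound 4 in this assay is a step of a 1.2-fold higher number from compound 2 to compound 4 (0.06 log units; within the scatter), that is, no change beyond the scatter, and the estimate is 4000 nM with a range of 1200 nM to 15000 nM.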

Compound 4, half-maximal cytotoxic concentration: 3650 nM
Compound 4: the middle estimate sits 1.1-fold (0.04 log units) above what was measured, and the stated range covers the measured number.
By their numbers in this assay, from the lowest: compounds 1, 2 and 4 (each within the scatter of the next); then compound 3.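

In this assay a 1.1-fold higher number from compound 2 to compound 4 (0.02 log units; within the scatter) and a 1.2-fold higher number from compound 1 to compound 4 (0.09 log units; within the scatter) extend what was seen at this position, on a nitrogen on an aromatic ring, from an exchange of one small group for another to the entry of 2-(piperazin-1-yl)ethyl, which brings more heavy atoms, a six-membered non-aromatic ring with 2 hetero atoms and a hydrogen-bond donor. Across cyclopropyl, dimethoxymethyl and 2-(piperazin-1-yl)ethyl, the three values lie within the scatter of each other, so in these compounds neither the size of the group nor the added ring separates them in this read-out. No measurement bearing on the reason for this result is available.

Still open, from the compounds shown here alone, is whether the same holds for other groups on this nitrogen, such as a carboxylic acid, a simple primary amine or a longer chain ending in an aromatic ring. Among the compounds shown here, also open is what sets compound 3 apart at 82100 nM, since it differs from the other compounds in more than one place and no single step connects it to them.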